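Fluoro for hydrogen on the benzoyl of compound 1

The source may report more compounds than this note shows. Statements on the series, on what has been measured and on what is new or still open speak of the compounds shown alone.

Measured so far:
compound 1 `O=C(c1ccccc1)N1CCC(NCCSC(c2ccc(F)cc2)c2ccc(F)cc2)CC1`: 4.51 nM
compound 2 `CC(C)(C)C(=O)N1CCC(NCC[S+]([O-])C(c2ccc(F)cc2)c2ccc(F)cc2)CC1`: 10200 nM

In an assay on membranes from striatum (strain Sprague-Dawley) for displacement of a labelled ligand from sodium-dependent dopamine transporter (Rattus norvegicus), read by scintillation counting, with a stated time of 120 min (on this read-out lower numbers stand for stronger inhibition and higher numbers for weaker inhibition), compound 1 gives 4.51 nM, the lower of the two numbers. Compound 2 gives 10200 nM, a gap beyond the usual scatter. Compound 3 `O=C(c1ccccc1F)N1CCC(NCCSC(c2ccc(F)cc2)c2ccc(F)cc2)CC1` differs from compound 1 by fluoro in place of hydrogen on an aromatic carbon. Among the measured compounds shown here, no step between measured compounds shows this change, so nothing beyond the scatter is expected in this assay in either direction. The expected step is a 1.2-fold higher number from compound 1 to compound 3 (0.09 log units; within the scatter). Compound 3 is estimated at 5.5 nM, with a range of 2 nM to 16 nM.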

Compound 3, inhibition constant: 46.1 nM
Compound 3: the middle estimate sits 8.4-fold (0.92 log units) below what was measured; measured number outside the range, above it.
By their numbers in this assay, from the lowest: compound 1; then compound 3; then compound 2.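

In this assay, the benzoyl ring of compound 1 proves sensitive to a single change: phenyl to 2-fluorophenyl gives a 10-fold higher number from compound 1 to compound 3 (1.01 log units; beyond the scatter) and weakens inhibition. One fluoro on this aromatic carbon, ortho to a large group, is therefore enough to move the number beyond the scatter. No measurement at hand gives a cause for this step.

Open, as far as these compounds go, is whether the step is specific to fluoro or to this carbon. A methoxy group or an amine here, or fluoro on another carbon of the same ring, would test this.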